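Swapping the aryl group on the shared core

The compounds below may be only part of what the source reports. "The series", "measured", "known", "first", "only" and "open" are said of these compounds alone.

Measured:
compound 1 `COc1ccccc1C1C(C#N)=C(N)N(c2ccc(S(N)(=O)=O)cc2)C2=C1CCCC2` — 30%
compound 2 `N#CC1=C(N)N(c2ccc(S(N)(=O)=O)cc2)C2=C(CCCC2)C1c1c(O)ccc2ccccc12` — 10%

In a functional assay on Ehrlich cells (Mus musculus) for cytotoxicity, read by trypan blue exclusion, with a stated time of 2 h, tested at 10 ug/mL (on this read-out higher numbers stand for a stronger effect at the one concentration tested and lower numbers for a weaker effect), compound 2 stands lowest of the two numbers; its nearest neighbour is compound 1, whose value is higher a number 20 percentage points lower from compound 1 to compound 2 (beyond the scatter). Compound 3 `Cc1ccc(C2C(C#N)=C(N)N(c3ccc(S(N)(=O)=O)cc3)C3=C2CCCC3)o1` differs from compound 2 by 5-methylfuran-2-yl in place of 2-hydroxynaphthalen-1-yl on a saturated ring carbon. Going by the values given here, the only step that bears on this change is a number 20 percentage points lower from compound 1 to compound 2 (beyond the scatter), where a smaller aryl group on the same saturated ring carbon went with the higher number. Compound 3 is therefore expected to move upward, by a modest a number 15 percentage points higher from compound 2 to compound 3 (beyond the scatter), though a single step makes this uncertain. Compound 3 is estimated at 25%, within 5% to 45%.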

Compound 3, a percentage reported as activity, at one concentration (the size of the read-out at that concentration, not a potency): 0%
For compound 3 the middle estimate is 25 percentage points above the measured one, outside the stated range (below it).
By their numbers in this assay, from the lowest: compounds 3 and 2 (each within the scatter of the next); then compound 1.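

In this assay the 5-methylfuran-2-yl group, smaller than 2-hydroxynaphthalen-1-yl, does not restore the number: the data show a number 10 percentage points lower from compound 2 to compound 3 (within the scatter) and so do not separate these two compounds. Measured against the 2-methoxyphenyl group, the data show a number 30 percentage points lower from compound 1 to compound 3 (beyond the scatter) and thus set compound 1 apart, so the size of the group on the saturated ring carbon does not by itself order the three compounds. Nothing available here accounts for this result.

On these data alone, it remains open whether the methoxy group or the phenyl ring of compound 1 goes with its higher number. Also open, as far as these compounds go, is where an unsubstituted phenyl or a 2-aminophenyl group on this carbon would fall.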